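A few compounds are considered here, and "the series" means these few. Any claim that something is new, unique, unknown or untested is made for them only; others in the source may bear on it.

Working notes on the series. In a functional assay on NCI-H460 cells (Homo sapiens) for inhibition, read by MTT assay, with a stated time of 24 h, tested at 1 ug/mL (a lower number here means less inhibition of growth, a higher number more inhibition of growth at the concentration tested), compound 1 `O=C(O)CCCCC(CCSC(=O)c1ccccc1)SC(=O)c1ccccc1` gives 0.77%, compound 2 `O=C(CCCCC(CCSC(=O)c1ccccc1)SC(=O)c1ccccc1)Nc1ccccc1` gives 5.93% and compound 3 `O=C(CCCCC(CCSC(=O)c1ccccc1)SC(=O)c1ccccc1)Nc1cccc(Cl)c1` gives 9.48%. Compound 3 therefore cannot be separated from either of the other two, and no order is claimed among the three.

Compound 4 `O=C(CCCCC(CCSC(=O)c1ccccc1)SC(=O)c1ccccc1)Nc1ccc(Cl)cc1` differs from compound 3 in one place: 4-chlorophenyl in place of 3-chlorophenyl on an amide-type nitrogen. In words, this is 4-chlorophenyl in place of 3-chlorophenyl on an amide-type nitrogen.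

For the measured compounds named here, three measured steps bear on this change, though only indirectly: a number 5.2 percentage points higher from compound 1 to compound 2 (within the scatter), a number 8.7 percentage points higher from compound 1 to compound 3 (within the scatter) and a number 3.6 percentage points higher from compound 2 to compound 3 (within the scatter). All three stay within the scatter. Going by the values given here, the last of them, which adds the chloro group, is the closest precedent. Among the compounds with values here, no measured pair compares two chlorophenyl isomers, so the data offer no direct precedent and no basis for a direction.

No step beyond the scatter is expected in this assay. The estimated step is a number 0.5 percentage points lower from compound 3 to compound 4 (within the scatter). For compound 4 the expected value is 9%, with an estimated range of 2% to 21%.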

Compound 4, percent growth inhibition at one concentration: 9.8%
Compound 4: middle estimate off by 0.8 percentage points, on the low side, within the range that was stated.
By their numbers in this assay, from the lowest: compounds 1, 2, 3 and 4 (each within the scatter of the next).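

In this assay, for the compounds shown here, 4-chlorophenyl in place of 3-chlorophenyl on the amide-type nitrogen gives a number 0.3 percentage points higher from compound 3 to compound 4 (within the scatter) and is the first direct comparison of two chlorophenyl isomers, which shows no separation between them. The other two new steps, a number 3.9 percentage points higher from compound 2 to compound 4 (within the scatter) for chloro in place of hydrogen on an aromatic carbon and a number 9 percentage points higher from compound 1 to compound 4 (within the scatter), also stay within the scatter, so no order is claimed among the four compounds. Nothing available bears on why these readings do not separate.

Going by these compounds, whether a methoxy or nitrile group on the phenyl ring would give a step beyond the scatter remains open. So does the effect of a benzylamine or a morpholine amide in place of the anilino group.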